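The source may report more compounds than this note shows. Statements on the series, on what has been measured and on what is new or still open speak of the compounds shown alone.

Of the compounds shown here, three have so far been measured in a physicochemical assay for lipophilicity; a higher number here means a more lipophilic compound, a lower number a more polar compound. Compound 1 `CNC(=O)c1cc(C(=O)N[C@H]2CC[C@H](OC)CC2)c([C@@H](C)c2ccccc2)o1` gives 4.1, compound 2 `CNC(=O)c1cc(C(=O)NC2CC2)cn(Cc2cccc3[nH]ccc23)c1=O` gives 2.9, and compound 3 `CCCNC(=O)c1cc(C(=O)NC)nn1[C@@H](C)c1ccccc1` gives 4.4. The number for compound 3 lies within the usual scatter of that for compound 1, but clearly beyond the scatter of that for compound 2, which is the most polar of the three. Compound 4 `CNC(=O)c1cc(C(=O)NC)n([C@@H](C)c2ccccc2)n1` has not yet been measured. It differs from compound 3 in one place: hydrogen in place of ethyl on a saturated chain carbon bound to an amide-type nitrogen. Among the measured compounds shown here, no measured pair shows this exact change, so its size is a judgement rather than a reading; the step of a number 0.90 log units lower from compound 3 to compound 4 (beyond the scatter) is expected to be a drop beyond the scatter. Compound 4 is therefore estimated at 3.5, with a likely range from 3 to 4.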

Compound 4, distribution coefficient: 3
Compound 4: middle estimate off by 0.50 log units, on the high side; the range from low to high includes it.
By their numbers in this assay, from the lowest: compounds 2 and 4 (each within the scatter of the next); then compounds 1 and 3 (each within the scatter of the next).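

Shortening propylcarbamoyl to methylcarbamoyl in this assay gives a number 1.40 log units lower from compound 3 to compound 4 (beyond the scatter) and is the only single-place step shown in this series. It shows that this chain position is not silent: removing ethyl at this place, with the rest of the molecule unchanged, moves the number well past the scatter. No evidence available here explains the size of this step. Going by these compounds, whether ethylcarbamoyl would fall partway along this step remains open. So does what a longer chain such as butyl, or a chain ending in an amine or a carboxylic acid, would give at this place.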